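The compounds below may be only part of what the source reports. "The series", "measured", "known", "first", "only" and "open" are said of these compounds alone.

Compound 1 `C=C1C[C@]23C[C@@]1(O)CC[C@H]2c1ccc(O)c(C)c1[C@@H]3Cn1cc(-c2ccccn2)nn1` carries the shared core with a pyridin-2-yl group on its five-membered aromatic ring. In a functional assay on SW480 cells (Homo sapiens) for cytotoxicity, read by MTT assay, with a stated time of 4 days (a higher number here means a weaker inhibitor, a lower number a stronger inhibitor), compound 1 gives > 20000 nM, which is a limit of the assay and not a measured number. Compound 2 `C=C1C[C@]23C[C@@]1(O)CC[C@H]2c1cc(Br)c(O)c(C)c1[C@@H]3Cn1cc(-c2ccccn2)nn1` has a bromo in place of hydrogen on an aromatic carbon. In this assay compound 2 gives > 20000 nM, again only a limit. The step from compound 1 to compound 2 is a step that the two limits leave unreadable from compound 1 to compound 2, so its size cannot be read. Compound 3 `Cc1ccc(S(=O)(=O)Oc2ccc3c(c2C)[C@H](Cn2cc(-c4ccc(Br)cc4)nn2)[C@@]24CC(=O)[C@@](C)(CC[C@@H]32)C4)cc1` is built on a different version of the core. In this assay compound 3 gives > 20000 nM, once more a limit. Within the data shown here, all three values therefore sit at the limit of > 20000 nM in this assay, at which 3 of the 3 values shown sit, and no measured step has a readable size.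

Compound 4 `C=C1C[C@]23C[C@@]1(O)CC[C@H]2c1ccc(O)c(C)c1[C@@H]3Cn1cc(-c2ccc(C)cc2)nn1` has not yet been measured. It differs from compound 1 by 4-methylphenyl in place of pyridin-2-yl on an aromatic carbon. Among the measured compounds shown here, no measured step involves this change, and the one measured step, from compound 1 to compound 2 a step that the two limits leave unreadable from compound 1 to compound 2, is unreadable. Because every value sits at the limit of > 20000 nM in this assay, at which 3 of the 3 values shown sit, compound 4 is expected to give a limit as well. Compound 4 is estimated at 30000 nM, with a range from 8000 nM to 100000 nM. The expected step from compound 1 to compound 4 is a step that the limit leaves unreadable from compound 1 to compound 4, estimated as nothing beyond the scatter.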

Compound 4, half-maximal inhibitory concentration: > 20000 nM
Compound 4 gave a limit, no number; the forecaster's own chance of this, stated with the estimate: 75%; the middle value does not contradict the limit.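

In this assay compound 4 gives > 20000 nM, which is a limit and not a measured number. Compound 1 also stands at a limit, so the step between compound 1 and compound 4 cannot be read. The compounds shown leave open how strongly any of them acts on these cells, because all share one value: the limit of > 20000 nM in this assay, at which 4 of the 4 values shown sit.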